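Compound 4: 2-methylbenzyl in place of 3-chlorobenzyl

A few compounds are considered here, and "the series" means these few. Any claim that something is new, unique, unknown or untested is made for them only; others in the source may bear on it.

For the measured compounds named here, compound 1 `O=C(O)c1ccccc1-c1ccc(CCc2ncc(Cc3cccc(Cl)c3)[nH]2)cc1` gives 31 nM in an in vitro functional assay on cells for agonist activity at Bombesin receptor subtype-3 (Mus musculus), read by luminescence and calcium flux (on this read-out lower numbers stand for an effect already at smaller amounts and higher numbers for an effect only at larger amounts of compound), the lowest of the three numbers measured so far. Compound 2 `O=C(O)c1ccccc1-c1ccc(CCc2ncc(-c3ccccc3)[nH]2)cc1` gives 872 nM and compound 3 `N#Cc1ccc(Cc2cnc(CCc3ccc(-c4ccccc4C(=O)O)cc3)[nH]2)cc1` gives 723 nM; the steps read a 28-fold higher number from compound 1 to compound 2 (1.45 log units; beyond the scatter) and a 23-fold higher number from compound 1 to compound 3 (1.37 log units; beyond the scatter), whereas a 1.2-fold lower number from compound 2 to compound 3 (0.08 log units; within the scatter). Compound 4 `Cc1ccccc1Cc1cnc(CCc2ccc(-c3ccccc3C(=O)O)cc2)[nH]1` is still to be measured; it differs from compound 1 as follows: 2-methylphenyl in place of 3-chlorophenyl on a saturated chain carbon bound to an aromatic carbon. Both large steps bear on this position: removing the benzyl or exchanging its aryl cost much of the effect of compound 1. Since the number rose sharply in a 23-fold higher number from compound 1 to compound 3 (1.37 log units; beyond the scatter) when the aryl on this saturated chain carbon was exchanged, a rise is expected here as well, though a smaller one. For compound 4 the expected step is a 3.5-fold higher number from compound 1 to compound 4 (0.55 log units; beyond the scatter). Compound 4 is therefore estimated at 110 nM, within 30 nM to 400 nM.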

Compound 4, half-maximal effective concentration: 9.3 nM
The estimate for compound 4 lay 12-fold (1.07 log units) above the measured number; measured number outside the range, below it.
By their numbers in this assay, from the lowest: compound 4; then compound 1; then compounds 3 and 2 (each within the scatter of the next).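

The aryl on this saturated chain carbon can also lower the number: 2-methylphenyl in place of 3-chlorophenyl gives (a 3.3-fold lower number from compound 1 to compound 4 (0.52 log units; beyond the scatter)), whereas the earlier exchange only raised it. The gaps to the other two compounds are far larger, with (a 78-fold lower number from compound 3 to compound 4 (1.89 log units; beyond the scatter)) for the 4-cyanophenyl exchange and (a 94-fold lower number from compound 2 to compound 4 (1.97 log units; beyond the scatter)) for 2-methylbenzyl in place of phenyl on an aromatic carbon, so the number depends strongly on the group held here. No available evidence accounts for these steps.

As far as these compounds go, compound 4 changes both the substituent and its place on the ring, so the share of each in the step stays open. From the compounds shown here alone, how an amine on this aryl, or a longer chain carrying it, would read also remains open.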